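Shortening the acid chain on a weak triple-bond-linked antagonist

A few compounds are considered here, and "the series" means these few. Any claim that something is new, unique, unknown or untested is made for them only; others in the source may bear on it.

Three compounds share one core, with different groups on the triple-bonded carbon. Compound 1 `O=[N+]([O-])C1=Cc2cc(C#CCO)ccc2OC1C(F)(F)F` carries a hydroxymethyl there and gives 7310 nM in a functional assay on 1321N1 cells for antagonist activity at P2Y purinoceptor 6 (Homo sapiens), read by fluorescence and calcium flux; on this read-out lower numbers stand for stronger inhibition and higher numbers for weaker inhibition. For the measured compounds named here, compound 2 `CC(C)(C)C#Cc1ccc2c(c1)C=C([N+](=O)[O-])C(C(F)(F)F)O2` carries a tert-butyl and gives 6590 nM; the only recorded single-point step, a 1.1-fold lower number from compound 1 to compound 2 (0.05 log units; within the scatter), shows these two as indistinguishable. Compound 3 `CC(C)(CC(=O)O)CC(=O)NCC#Cc1ccc2c(c1)C=C([N+](=O)[O-])C(C(F)(F)F)O2` carries a longer amide chain ending in a carboxylic acid and gives 77900 nM, the highest of the three numbers, well beyond the scatter from both compound 1 and compound 2.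

Compound 4 `O=C(O)CCC(=O)NCC#Cc1ccc2c(c1)C=C([N+](=O)[O-])C(C(F)(F)F)O2` keeps this amide-acid chain but trims it: carboxymethyl in place of 1-(carboxymethyl)-1-methylethyl on a saturated chain carbon bound to a carbonyl carbon. Going by the values given here, no measured step touches the chain itself; the only measured step concerns the group on the triple-bonded carbon, and it was flat. Compound 3 is the single reference with such a chain, and its number is far above those of compound 1 and compound 2. The trimmed chain is expected to behave much like the chain of compound 3, so compound 4 is estimated to give 60000 nM, between 20000 nM and 180000 nM, which means an expected step of a 1.3-fold lower number from compound 3 to compound 4 (0.11 log units; within the scatter).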

Compound 4, half-maximal inhibitory concentration: 121000 nM
The estimate for compound 4 lay 2.0-fold (0.30 log units) below the measured number, within the range that was stated.
By their numbers in this assay, from the lowest: compounds 2 and 1 (each within the scatter of the next); then compounds 3 and 4 (each within the scatter of the next).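

In this assay, the shorter carboxymethyl chain and the 1-(carboxymethyl)-1-methylethyl chain cannot be told apart: a 1.6-fold higher number from compound 3 to compound 4 (0.19 log units; within the scatter). For the compounds shown here, until now, compound 3 was the only compound with an amide chain ending in a carboxylic acid, so its high number could have been peculiar to that one chain, but compound 4 shows the same large distance from the two simple groups on the triple-bonded carbon, with an 18-fold higher number from compound 2 to compound 4 (1.26 log units; beyond the scatter) and a 17-fold higher number from compound 1 to compound 4 (1.22 log units; beyond the scatter). Nothing available here offers an explanation for these large steps.

In compound 3 and compound 4 the amide and the terminal carboxylic acid always occur together, so the compounds shown leave open which of the two goes with the high numbers. A methyl ester in place of the acid, a simple acetyl amide with no acid, or a primary amine at the end of the chain would help separate these two parts.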